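The compounds below may be only part of what the source reports. "The series", "measured", "known", "first", "only" and "open" are said of these compounds alone.

The series rests on two cores. Compound 1 `O=C1C=C(N2CCCC2)CN1c1ccc(Cl)cc1` and compound 2 `O=C1C=C(N2CCNCC2)CN1c1ccc(Cl)cc1` share one core; compound 3 `O=C1C=C(N2CCNCC2)C(=O)N1c1ccc(Cl)cc1` and the as yet unmeasured compound 4 `O=C1C=C(N2CCCC2)C(=O)N1c1ccc(Cl)cc1` share the other, and the difference between the two cores is not broken down here. In a physicochemical assay for lipophilicity (a higher number here means a more lipophilic compound, a lower number a more polar compound), compound 1 gives 2.6, compound 2 gives 3 and compound 3 gives 3.4, the highest of the three. Within the first core the change pyrrolidin-1-yl in place of piperazin-1-yl on a double-bonded ring carbon produced a step of a number 0.40 log units lower from compound 2 to compound 1 (beyond the scatter). The same change, (pyrrolidin-1-yl in place of piperazin-1-yl on a double-bonded ring carbon), now links compound 3 to compound 4. Within the data shown here, since both differences read the same word for word, a step of similar size is expected, so that compound 4 is estimated at 3 in this assay, between 2.6 and 3.4, because the earlier step of a number 0.40 log units lower from compound 2 to compound 1 (beyond the scatter) is the only guide. That expectation means a step of a number 0.40 log units lower from compound 3 to compound 4 (beyond the scatter).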

Compound 4, partition coefficient: 3
Beside the measured number, compound 4's estimate shows no gap at the digits printed; the range from low to high includes it.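

In this assay the step of a number 0.40 log units lower from compound 3 to compound 4 (beyond the scatter) matches the step of a number 0.40 log units lower from compound 2 to compound 1 (beyond the scatter) at the digits printed, so pyrrolidin-1-yl in place of piperazin-1-yl on a double-bonded ring carbon carried over from the core of compound 1 to the core of compound 3 with its size intact. This rests on just two cores and one assay, so it does not show that the change would carry over to any further core or to another read-out. Nothing given here explains why the two steps agree. The compounds shown leave open whether the match would hold for other groups on that double-bonded ring carbon, such as morpholin-4-yl or an open-chain diethylamino group.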